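Nitro for chloro on the pendant phenyl ring

The source may report more compounds than this note shows. Statements on the series, on what has been measured and on what is new or still open speak of the compounds shown alone.

Measured compounds:
compound 1, `O=[N+]([O-])c1cccc(-c2nn(-c3ccccc3)cc2C(Nc2nc3ccccc3s2)c2c(O)ccc3ccccc23)c1`: 32000 nM
compound 2, `Oc1ccc2ccccc2c1C(Nc1nc2ccccc2s1)c1cn(-c2ccccc2)nc1-c1cccc(Cl)c1`: 20400 nM
compound 3, `COc1ccc2nc(NC(c3cn(-c4ccccc4)nc3-c3ccc(Cl)cc3)c3c(O)ccc4ccccc34)sc2c1`: 34500 nM

All three were tested in a functional assay on A549 cells (Homo sapiens) for antiproliferative activity, read by MTT assay, with a stated time of 48 h; on this read-out lower numbers stand for stronger inhibition and higher numbers for weaker inhibition. In this assay, among the compounds with values here, compound 2 gives 20400 nM and compound 1 gives 32000 nM; the step of a 1.6-fold higher number from compound 2 to compound 1 (0.20 log units; within the scatter) is the one counted change in this set, (nitro in place of chloro on an aromatic carbon). Compound 3 gives 34500 nM, and its numbers against compound 1 and compound 2 all lie within the scatter, so no order among the three can be read from this assay. The difference between the core of compound 3 and the core of compound 2 is not broken down here.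

Compound 4, `COc1ccc2nc(NC(c3cn(-c4ccccc4)nc3-c3ccc([N+](=O)[O-])cc3)c3c(O)ccc4ccccc34)sc2c1`, has not been measured. It is related to compound 3 by nitro in place of chloro on an aromatic carbon. This is the same kind of change as that from compound 2 to compound 1, not the same change: in compound 1 the nitro sits meta to a large group, in compound 4 it sits para to a large group, and the two pairs rest on different cores.

Within the data shown here, the only precedent is the step of a 1.6-fold higher number from compound 2 to compound 1 (0.20 log units; within the scatter), which lay within the scatter. On that basis the step of a 1.3-fold higher number from compound 3 to compound 4 (0.12 log units; within the scatter) is expected to be small. Compound 4 is estimated at 45000 nM in this assay, with a range from 20000 nM to 100000 nM, because compound 3 starts from 34500 nM and the earlier nitro-for-chloro step moved the number only a little.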

Compound 4, half-maximal inhibitory concentration: 22500 nM
Compound 4: middle estimate off by 2.0-fold (0.30 log units), on the high side; the measured number falls inside the stated range.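

In this assay, nitro in place of chloro, here 4-chlorophenyl to 4-nitrophenyl, gives a 1.5-fold lower number from compound 3 to compound 4 (0.19 log units; within the scatter), so on this core the change stays as small as it did on the core of compound 1. The two steps point in opposite directions on paper, but that does not amount to a difference between the cores: the same change on two cores in this assay, a 1.6-fold higher number (0.20 log units; within the scatter) from compound 2 to compound 1 and a 1.5-fold lower number (0.19 log units; within the scatter) from compound 3 to compound 4, 2.4-fold (0.38 log units) apart, within the scatter of two such steps. Within the data shown here, this supports only a modest statement, that in these two pairs the swap moved the number by no more than the assay can resolve; it does not show that nitro and chloro are interchangeable across the series, and with only two pairs, neither step beyond the scatter, it gives no direction for the change on any further core.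

Going by these compounds, all four compounds carry either chloro or nitro on the pendant phenyl ring, so the effect of an amine, a carboxylic acid or a nitrile at that place remains open, as does that of a phenyl ring with no such group at all. Also open, on these data alone, is what happens to the number when the hydroxyl group shared by all four compounds is replaced, for instance by a methoxy group.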